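Anilide in place of methylpiperazine amide on a diaryl thiophene

The source may hold more compounds than are shown below. What is called first, only, known or untested is meant among the compounds shown, and "the series" means these compounds.

Measured compounds:
- compound 1 `CN1CCN(C(=O)c2c(N)sc(-c3ccc(Cl)cc3)c2-c2ccc(Cl)cc2)CC1`: 590 nM
- compound 2 `CC1CCN(C(=O)c2c(N)sc(-c3ccc(Cl)cc3)c2-c2ccc(Cl)cc2)CC1`: 1750 nM
- compound 3 `CS(=O)(=O)Nc1sc(-c2ccc(Cl)cc2)c(-c2ccc(Cl)cc2)c1C(=O)NC1CC1`: "not determined" (no result reported)

Compounds 1 and 2 share one core and differ only in the group on the carbonyl carbon. In a functional assay on A549 cells (Homo sapiens) for inhibition, read by sulforhodamine B assay, with a stated time of 72 h (a higher number here means a weaker inhibitor, a lower number a stronger inhibitor), compound 1 gives 590 nM and has the lowest number of the two that were measured; compound 2 gives 1750 nM. Within the data shown here, the one measured step, a 3.0-fold higher number from compound 1 to compound 2 (0.47 log units; beyond the scatter), shows that putting 4-methylpiperidin-1-yl in place of 4-methylpiperazin-1-yl on the carbonyl carbon makes the inhibitor weaker by a modest amount that lies beyond the scatter. Compound 3 carries a cyclopropylamide and a methanesulfonamide, and in this assay compound 3 is recorded as "not determined" (no result reported), so it gives no guidance here.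

Compound 4 `Nc1sc(-c2ccc(Cl)cc2)c(-c2ccc(Cl)cc2)c1C(=O)Nc1ccccc1` is compound 1 with the change (anilino in place of 4-methylpiperazin-1-yl on a carbonyl carbon). Among the measured compounds shown here, this is the same place that was changed in going from compound 1 to compound 2, and the only measured step that bears on it is a 3.0-fold higher number from compound 1 to compound 2 (0.47 log units; beyond the scatter). Since that replacement of 4-methylpiperazin-1-yl gave a higher number, the anilide is expected to give a higher number too, with a step of about a 3.4-fold higher number from compound 1 to compound 4 (0.53 log units; beyond the scatter). The estimate for compound 4 in this assay is therefore 2000 nM, with a range from 600 nM to 7000 nM.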

Compound 4, half-maximal inhibitory concentration: 25000 nM
Compound 4: middle estimate off by 13-fold (1.10 log units), on the low side, and the stated range ends below it.
By their numbers in this assay, from the lowest: compound 1; then compound 2; then compound 4.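

In this assay, the group on the carbonyl carbon proves able to move the number much further than the earlier pair showed: anilino in place of 4-methylpiperazin-1-yl gives a 42-fold higher number from compound 1 to compound 4 (1.63 log units; beyond the scatter), and anilino in place of 4-methylpiperidin-1-yl gives a 14-fold higher number from compound 2 to compound 4 (1.15 log units; beyond the scatter). Both steps are large and beyond the scatter, so this position accepts 4-methylpiperidin-1-yl at the modest cost of a 3.0-fold higher number from compound 1 to compound 2 (0.47 log units; beyond the scatter), while the anilide of compound 4 falls well behind both compound 1 and compound 2. Nothing available explains why this change costs so much more than the earlier one.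

The change swaps a non-aromatic ring for an aromatic one and also brings in the amide hydrogen, and these three compounds cannot separate the two, so an N-methylanilide and a cyclohexylamino amide would be the telling groups at this place. Also open, from the compounds shown here alone, is whether a phenyl ring carrying a dimethylamino group or a carboxylic acid would recover any of the lost inhibition, and the cyclopropylamide of compound 3 gives no number to help.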